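A few compounds are considered here, and "the series" means these few. Any claim that something is new, unique, unknown or untested is made for them only; others in the source may bear on it.

Compound 1 `Cc1ccc(NC(=O)CSc2nnc(-c3ccoc3C)n2Cc2ccco2)cc1` gives > 15800 nM in a functional assay on CHO cells for antagonist activity at Orexin/Hypocretin receptor type 1 (Homo sapiens), read by FLIPR and calcium flux (a lower number here means a stronger inhibitor, a higher number a weaker inhibitor), which is a limit of the assay.
Compound 2 `Cc1occc1-c1nnc(SCC(=O)Nc2ccc(Cl)cc2)n1Cc1ccco1` gives 2000 nM in this assay.
Compound 3 `COc1ccc(NC(=O)CSc2nnc(-c3ccoc3C)n2Cc2ccco2)cc1` gives > 15800 nM in this assay, again a limit of the assay.

Compound 3 therefore stands at the limit, where compound 1 also sits (the limit of > 15800 nM in this assay, at which 2 of the 3 values shown sit); only compound 2 returns a number. Compound 4 `CC(=O)c1ccc(NC(=O)CSc2nnc(-c3ccoc3C)n2Cc2ccco2)cc1` differs from compound 3 by acetyl in place of methoxy on an aromatic carbon. Among the measured compounds shown here, no measured step swaps methoxy for acetyl. The nearest comparison is an at least 7.9-fold higher number from compound 2 to compound 3 (0.89 log units; beyond the scatter), while a step that the two limits leave unreadable from compound 1 to compound 3 cannot be read from the two limits. Acetyl is a third group at the same place, so the expectation rests on thin ground. The step from compound 3 to compound 4 is expected to be an at least 1.9-fold lower number from compound 3 to compound 4 (0.29 log units; that floor lies within the scatter). Compound 4 is estimated at 8000 nM, ranging from 1500 nM to 30000 nM.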

Compound 4, inhibition constant: 2510 nM
Compound 4: middle estimate off by 3.2-fold (0.50 log units), on the high side; the measured number falls inside the stated range.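

Chloro is no longer the only group at this place on the aromatic ring to give a readable number, as acetyl does too, with an at least 6.2-fold lower number from compound 3 to compound 4 (0.79 log units; beyond the scatter) and an at least 6.2-fold lower number from compound 1 to compound 4 (0.79 log units; beyond the scatter). On these data alone, both steps start from a limit of the assay, so their full size stays unknown: the limit of > 15800 nM in this assay, at which 2 of the 4 values shown sit. Acetyl and chloro cannot be told apart, with a 1.3-fold higher number from compound 2 to compound 4 (0.10 log units; within the scatter).

As far as these compounds go, whether an amine, a carboxylic acid or a longer chain at this place would also give a readable number remains open.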